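The source may hold more compounds than are shown below. What is called first, only, known or untested is meant among the compounds shown, and "the series" means these compounds.

Three members of the series have been run so far, all carrying the same core with a variable group on an aromatic carbon. Compound 1 `Cc1cc(C(=O)NCc2ccncc2)nn1Cc1cc(Cl)ccc1OCc1ccccc1` gives 79.4 nM in an assay on CHO-K1 cells for displacement of a labelled ligand from prostaglandin E2 receptor EP1 subtype (Homo sapiens); a lower number here means a stronger inhibitor, a higher number a weaker inhibitor. Compound 2 `Cc1cc(NC(=O)C2CCOCC2)nn1Cc1cc(Cl)ccc1OCc1ccccc1` gives 63.1 nM in this assay, and compound 3 `Cc1cc(NC(=O)OCc2ccccn2)nn1Cc1cc(Cl)ccc1OCc1ccccc1` gives 79.4 nM in this assay. Compound 3 sits level with compound 1; its only separation from the rest is a 1.3-fold higher number from compound 2 to compound 3 (0.10 log units; within the scatter), and the other two steps, a 1.3-fold lower number from compound 1 to compound 2 (0.10 log units; within the scatter) and no change at the digits printed from compound 1 to compound 3 (within the scatter), are just as small. None of the three exchanges has moved the number beyond the scatter.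

Compound 4 `Cc1cc(NC(=O)O[C@H]2CCOC2)nn1Cc1cc(Cl)ccc1OCc1ccccc1` is the next member awaiting data. It differs from compound 3 by oxolan-3-yl in place of (pyridin-2-yl)methyl on an oxygen next to a carbonyl group. The measured step that bears most directly on this is a 1.3-fold higher number from compound 2 to compound 3 (0.10 log units; within the scatter), where oxan-4-yl was traded for (pyridin-2-yl)methoxy on the carbonyl carbon with no shift beyond the scatter; the present change again swaps a pyridinyl-bearing group for a small saturated oxygen heterocycle at the carbamate end. On that basis the expected step in this assay is a 1.0-fold higher number from compound 3 to compound 4 (0.00 log units; within the scatter), with no direction anticipated beyond the scatter. Compound 4 is therefore estimated at 80 nM, in a range from 40 nM to 160 nM.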

Compound 4, half-maximal inhibitory concentration: 79.4 nM
Compound 4: middle estimate off by 1.0-fold (0.00 log units), on the high side, within the range that was stated.
By their numbers in this assay, from the lowest: compounds 2, 1, 3 and 4 (each within the scatter of the next).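

Notes on the oxygen next to a carbonyl group: in this assay, oxolan-3-yl in place of (pyridin-2-yl)methyl gives no change at the digits printed from compound 3 to compound 4 (within the scatter), so at this position the number does not depend on the six-membered aromatic ring or its nitrogen, as a saturated five-membered ring with an oxygen serves equally well. The carbamate with oxolan-3-yl also stands level with the two other variants at the same aromatic carbon, with a 1.3-fold higher number from compound 2 to compound 4 (0.10 log units; within the scatter) and no change at the digits printed from compound 1 to compound 4 (within the scatter), so four quite different end groups now fall within the scatter of one another and no exchange in the series has yet separated two compounds. Nothing measured here accounts for this flat response.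

Still open, going by these compounds, is whether any group at this position can move the number beyond the scatter, for example a carboxylic acid, a primary amine or a longer alkyl chain on the carbamate oxygen. Also open, on these data alone, is whether the defined stereocentre of oxolan-3-yl matters, which would take the opposite stereoisomer to answer.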